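The source may hold more compounds than are shown below. What is called first, only, known or untested is meant among the compounds shown, and "the series" means these compounds.

In an ADME assay on J774 cells (Mus musculus) for cytotoxicity, read by MTT assay, with a stated time of 48 h (on this read-out lower numbers stand for stronger inhibition and higher numbers for weaker inhibition), compound 1 `O=S(=O)(/C=C/c1ccc2no[n+]([O-])c2c1)c1ccccc1` gives 16000 nM; 78000 nM (2 entries), compound 2 `O=C(/C=C/c1ccc2nonc2c1)c1ccccc1` gives 102000 nM and compound 3 `O=C(/C=C/c1ccc2nonc2c1)c1ccc(Cl)cc1` gives 251000 nM. Compound 3 therefore holds the higher of the two single numbers, while compound 1 offers no single number to set beside it.

Compound 4 `O=C(/C=C/c1ccc2nonc2c1)c1ccc([N+](=O)[O-])cc1` departs from compound 3 by one change, nitro in place of chloro on an aromatic carbon. Among the measured compounds shown here, no measured step makes this exchange directly. The closest evidence is the modest step that introduced the chloro, a 2.5-fold higher number from compound 2 to compound 3 (0.39 log units; beyond the scatter), so a step of similar modest size is expected in this assay. The direction is less secure, but a move down towards compound 2 at 102000 nM seems the more likely. The expected change is a 2.1-fold lower number from compound 3 to compound 4 (0.32 log units; beyond the scatter). The range is kept wide because the several entries of compound 1 in this assay, 16000 nM; 78000 nM (2 entries) lie well apart. For compound 4 the estimated value is 120000 nM, with an expected range of 45000 nM to 300000 nM.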

Compound 4, half-maximal inhibitory concentration: 131000 nM
Compound 4: middle estimate off by 1.1-fold (0.04 log units), on the low side; the measured number falls inside the stated range.
By their numbers in this assay, from the lowest: compounds 2, 4 and 3 (each within the scatter of the next, the first and the last beyond it).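

At this place on the aromatic ring, para to a large group, nitro in place of hydrogen gives only a 1.3-fold higher number from compound 2 to compound 4 (0.11 log units; within the scatter) in this assay, and nitro in place of chloro gives a 1.9-fold lower number from compound 3 to compound 4 (0.28 log units; within the scatter) in the same assay. The earlier compounds shown here showed a single substituent effect at this position, a 2.5-fold higher number from compound 2 to compound 3 (0.39 log units; beyond the scatter), whereas the nitro compound cannot be separated from either neighbour, so replacing hydrogen here does not always give a step beyond the scatter. Small steps need cautious reading, since repeat entries in this assay can lie far apart: the several entries of compound 1 in this assay, 16000 nM; 78000 nM (2 entries).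

The compounds shown leave open how an amine or a carboxylic acid at this place would read. They also leave open whether chloro or nitro would behave alike on the core of compound 1.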